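Working notes: from compound 3 to compound 4

This account rests on a few compounds, and the source may have more. Where it says the series, first, only, none or still open, it means among the compounds named here.

All values are from a functional assay on MKN-45 cells (Homo sapiens) for inhibition, with a stated time of 72 h; on this read-out higher numbers stand for weaker inhibition and lower numbers for stronger inhibition.

Compound 1 `COc1cc(C(=O)c2ccc3[nH]ccc3c2)cc(OC)c1OC`: 88 nM
Compound 2 `CCCn1ccc2cc(C(=O)c3cc(OC)c(OC)c(OC)c3)ccc21`: 680 nM
Compound 3 `COc1cc(C(=O)c2ccc3c(ccn3CC(=O)O)c2)cc(OC)c1OC`: 396 nM

Compound 3 stands with compound 2 and apart from compound 1. The data show a 1.7-fold lower number from compound 2 to compound 3 (0.23 log units; within the scatter), and also a 4.5-fold higher number from compound 1 to compound 3 (0.65 log units; beyond the scatter).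

The next structure is compound 4 `COc1cc(C(=O)c2ccc3c(ccn3CCN(C)C)c2)cc(OC)c1OC`, with (dimethylamino)methyl in place of carboxy on a saturated chain carbon bound to an aromatic nitrogen. The change keeps a substituent on the aromatic nitrogen and alters the end of the chain.

Within the data shown here, three measured steps bear on it. Among the measured compounds shown here, replacing hydrogen on the aromatic nitrogen with propyl gave a 7.7-fold higher number from compound 1 to compound 2 (0.89 log units; beyond the scatter), a modest step in the same direction as the one to compound 3. For the measured compounds named here, the only measured exchange at the chain end, carboxy in place of ethyl, gave a 1.7-fold lower number from compound 2 to compound 3 (0.23 log units; within the scatter). Going by the values given here, no measured compound carries an amine on the chain, so this expectation rests on those two chain ends alone.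

In this assay, no step beyond the scatter is therefore expected, and the expected step is a 1.3-fold lower number from compound 3 to compound 4 (0.12 log units; within the scatter). The estimate for compound 4 is 300 nM, with an expected range of 100 nM to 900 nM.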

Compound 4, half-maximal inhibitory concentration: 2900 nM
Estimate against measurement, compound 4: 9.7-fold (0.99 log units) below; measured number outside the range, above it.
By their numbers in this assay, from the lowest: compound 1; then compounds 3 and 2 (each within the scatter of the next); then compound 4.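

In this assay the end of the chain on the aromatic nitrogen proves to matter: with a substituent kept on that nitrogen, 2-(dimethylamino)ethyl gives a 7.3-fold higher number from compound 3 to compound 4 (0.86 log units; beyond the scatter) against carboxymethyl and a 4.3-fold higher number from compound 2 to compound 4 (0.63 log units; beyond the scatter) against propyl, whereas the two chain ends seen earlier stayed within the scatter of each other. Against the free nitrogen hydrogen of compound 1, the same group gives a 33-fold higher number from compound 1 to compound 4 (1.52 log units; beyond the scatter) as the largest step among the four compounds, so all three substituents shown at this position go with a higher number than hydrogen, by an amount that depends on the chain end. Nothing available here accounts for the separation of the amine-ended chain from the other two.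

The compounds shown leave open whether a cyclic amine such as morpholine, a shorter chain ending in dimethylamino, or a neutral end such as a primary amide or a hydroxy group would fall with propyl and carboxymethyl or with 2-(dimethylamino)ethyl. They also leave open whether a group as small as methyl on the aromatic nitrogen would stay within the scatter of compound 1.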